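A few compounds are considered here, and "the series" means these few. Any claim that something is new, unique, unknown or untested is made for them only; others in the source may bear on it.

Series with the shared core of compound 1 `C#CC(=O)N1C(c2ccc(C#N)cc2)SC[C@@H]1C(=O)OCC`, carrying a 4-cyanophenyl group on the saturated ring carbon; in a functional assay on Huh-7 cells (Homo sapiens) for inhibition, read by sulforhodamine B assay (on this read-out lower numbers stand for stronger inhibition and higher numbers for weaker inhibition), compound 1 gives 2600 nM. Compound 2 `C#CC(=O)N1C(CCCCC)SC[C@@H]1C(=O)OCC` carries pentyl there and gives 1800 nM in this assay. Compound 3 `C#CC(=O)N1C(c2cccc(F)c2)SC[C@@H]1C(=O)OCC` carries 3-fluorophenyl and gives 1400 nM in this assay. The three numbers all fall within the scatter of one another, compound 3 lying nearest compound 2; a 1.3-fold lower number from compound 2 to compound 3 (0.11 log units; within the scatter). The values of compound 1 and compound 3 likewise show no separation beyond the scatter.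

Compound 4 `C#CC(=O)N1C(c2ccc(F)cc2)SC[C@@H]1C(=O)OCC` is not yet measured. It differs from compound 3 only in the ring position of the fluorine: 4-fluorophenyl in place of 3-fluorophenyl on a saturated ring carbon. Within the data shown here, no measured step exchanges one fluorophenyl isomer for another, so no direct precedent exists; the nearest analogy is the pentyl-to-3-fluorophenyl step, which stayed within the scatter, and the 4-cyanophenyl of compound 1 also sits within the scatter of compound 3. A step of no more than the scatter is therefore expected in this assay for compound 4, a 1.2-fold higher number from compound 3 to compound 4 (0.08 log units; within the scatter). Compound 4 is estimated at 1700 nM in this assay, with a range from 800 nM to 3600 nM.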

Compound 4, half-maximal inhibitory concentration: 700 nM
Compound 4: middle estimate off by 2.4-fold (0.39 log units), on the high side; measured number outside the range, below it.
By their numbers in this assay, from the lowest: compounds 4, 3, 2 and 1 (each within the scatter of the next, the first and the last beyond it).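

In this assay, moving the fluorine around the aromatic ring at this position gives a 2.0-fold lower number from compound 3 to compound 4 (0.30 log units; within the scatter), so the two fluorophenyl isomers are not separated. Separation at this position first appears with 4-fluorophenyl: against pentyl the change gives a 2.6-fold lower number from compound 2 to compound 4 (0.41 log units; beyond the scatter), where 3-fluorophenyl in place of pentyl had stayed within the scatter, and fluoro in place of cyano on the aromatic carbon gives a 3.7-fold lower number from compound 1 to compound 4 (0.57 log units; beyond the scatter). No data at hand bear on what lies behind the size of these steps.

From the compounds shown here alone, whether 4-chlorophenyl or 4-methoxyphenyl on the same ring carbon would track with 4-fluorophenyl remains open. Also open, going by these compounds, is whether the steps at this position would hold with a carboxylic acid in place of the ethoxycarbonyl group.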